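Changing One Stereocentre in a Compound at the Limit

A few compounds are considered here, and "the series" means these few. Any claim that something is new, unique, unknown or untested is made for them only; others in the source may bear on it.

Measured compounds:
Compound 1, `CC(=O)CC/C=C(\C)CCC1=C(C)CCCC1(C)C`, gives > 15000 nM in a functional assay on MDA-MB-435 cells (Homo sapiens) for inhibition; a higher number here means a weaker inhibitor of growth, a lower number a stronger inhibitor of growth.
Compound 2, `CC1=C(CC/C(C)=C/CC[C@@]2(C)CC[C@@H]([C@H](C)C(=O)O)OO2)C(C)(C)CCC1`, gives > 100000 nM in this assay.

Both recorded values are limits of the assay rather than numbers. Compound 2 stands at the limit of > 100000 nM in this assay, at which 1 of the 2 values shown sits. Compound 1 stands at the limit of > 15000 nM in this assay, at which 1 of the 2 values shown sits. No step between two measured compounds is shown here, so the size of any change in this assay cannot be read from these two compounds alone.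

Compound 3, `CC1=C(CC/C(C)=C/CC[C@@]2(C)CC[C@H]([C@H](C)C(=O)O)OO2)C(C)(C)CCC1`, is the compound still to be measured. It differs from compound 2 in a single respect: the two compounds have the same atoms and bonds and differ only in configuration as drawn: 1 of 4 stereo elements differ; a stereocentre at a saturated ring carbon is drawn S in compound 2 and R in compound 3. Because compound 2 is reported only at the limit of > 100000 nM in this assay, at which 1 of the 2 values shown sits, the step from compound 2 to compound 3 in this assay is expected to stay within the scatter, and the expected step is a number no higher from compound 2 to compound 3 (the limit leaves the size open). Compound 3 is accordingly estimated at 100000 nM, with a range from 30000 nM to 300000 nM, most likely again reported only as a limit.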

Compound 3, concentration for 50% growth inhibition: > 5000 nM
Compound 3: a limit, no number; the forecaster's own chance of this, stated with the estimate: 85%; the middle value is on the limit's open side.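

In this assay compound 2 gives > 100000 nM, a limit and not a number. For the compounds shown here, compound 3 gives > 5000 nM, also a limit, so no step between these two compounds can be read. From the compounds shown here alone, whether the stereocentre at the saturated ring carbon affects growth inhibition stays open.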